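Solubility notes on compound 1 and its open-chain variant

The source may report more compounds than this note shows. Statements on the series, on what has been measured and on what is new or still open speak of the compounds shown alone.

Compound 1 `Cc1ccccc1-c1nc(CN2CCC(C(=O)NCCCN3CCC(C)CC3)CC2)c(C)o1` was run in a physicochemical assay for solubility, in phosphate buffer, measured as kinetic solubility, at pH 7.4; a higher number here means a more soluble compound, a lower number a less soluble compound. Compound 1 reaches only a limit of the assay there, > 67 ug/mL, the point named in the limit of > 67 ug/mL in this assay, at which 1 of the 3 values shown sits. Compound 2 `Cc1oc(-c2c(F)cccc2F)nc1CN1CCC(C(=O)NCCCN2C[C@H](C)C[C@H](C)C2)CC1` likewise gives only a limit in this assay, > 72 ug/mL, the point named in the limit of > 72 ug/mL in this assay, at which 1 of the 3 values shown sits. Compound 3 `Cc1oc(-c2c(Cl)cccc2Br)nc1CN1CCC(C(=O)NCCCN2C[C@H](C)C[C@H](C)C2)CC1` also stops at a limit in this assay, > 83 ug/mL, the point named in the limit of > 83 ug/mL in this assay, at which 1 of the 3 values shown sits. For the measured compounds named here, the one change with two measured ends, a step that the two limits leave unreadable from compound 2 to compound 3, therefore carries no readable size, and all three values shown are limits rather than numbers.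

Compound 4 `CCCN(CCC)CCNC(=O)C1CCN(Cc2nc(-c3ccccc3C)oc2C)CC1` is not yet measured. It differs from compound 1 by dipropylamino in place of (4-methylpiperidin-1-yl)methyl on a saturated chain carbon, two bonds along the chain from an amide-type nitrogen. Going by the values given here, no measured step in this set follows the same kind of change, and the single step between measured compounds is unreadable, so nothing here fixes a size or a direction for the move in this assay. The step that the limit leaves unreadable from compound 1 to compound 4 is expected to lie within the scatter. Compound 4 is estimated at 70 ug/mL in this assay, with a range from 30 ug/mL to 150 ug/mL, and a limit rather than a number is the likelier outcome.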

Compound 4, solubility: > 65 ug/mL
Compound 4 ended at the assay's limit; the forecaster's own chance of this, stated with the estimate: 65%; the middle value is on the limit's open side.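

In this assay compound 4 gives > 65 ug/mL, which is a limit and not a number. Compound 1 also stands at a limit, > 67 ug/mL. The step between compound 1 and compound 4 therefore cannot be read. The compounds shown leave open where any of the four actually sits in this assay, and whether dipropylamino in place of (4-methylpiperidin-1-yl)methyl changes the read-out at all.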